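Swapping Bromo for Methyl on the Outer Ring

This account rests on a few compounds, and the source may have more. Where it says the series, first, only, none or still open, it means among the compounds named here.

Among the measured compounds shown here, compound 2 `Cc1cccc2nc(N/N=C\c3ccc(Br)cc3)sc12` gives 20.1 ug/mL in a functional assay on cells (Erythrocyte, Homo sapiens) for inhibition, read by spectrophotometry and hemolysis, with a stated time of 10 min (a lower number here means a stronger inhibitor, a higher number a weaker inhibitor), the lower of the two numbers so far. Compound 1 `Cc1cccc2nc(N/N=C\c3ccccc3)sc12` carries hydrogen where compound 2 carries bromo; in this assay compound 1 gives 80.1 ug/mL. For the measured compounds named here, the only measured step, a 4.0-fold lower number from compound 1 to compound 2 (0.60 log units; beyond the scatter), shows that bromo in place of hydrogen brought a modest improvement.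

Compound 3 `Cc1ccc(/C=N\Nc2nc3cccc(C)c3s2)cc1` is not yet measured. It differs from compound 2 by methyl in place of bromo on an aromatic carbon

That single step bears only indirectly on this change, since methyl is neither the hydrogen of compound 1 nor the bromo of compound 2. Without a measured methyl analogue, a number somewhere between compound 1 and compound 2 seems most plausible, a modest rise from compound 2. Compound 3 is therefore expected to give about 40 ug/mL in this assay, most likely between 18 ug/mL and 90 ug/mL, an estimated step of a 2.0-fold higher number from compound 2 to compound 3 (0.30 log units; within the scatter).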

Compound 3, half-maximal inhibitory concentration: 54.3 ug/mL
Compound 3: the middle estimate sits 1.4-fold (0.13 log units) below what was measured, and the stated range covers the measured number.
By their numbers in this assay, from the lowest: compound 2; then compounds 3 and 1 (each within the scatter of the next).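

Methyl at this carbon, para to a large group, does not keep the gain seen with bromo: the swap gives a 2.7-fold higher number from compound 2 to compound 3 (0.43 log units; beyond the scatter) in this assay and so takes back much of what bromo brought. Set against hydrogen, methyl shows a 1.5-fold lower number from compound 1 to compound 3 (0.17 log units; within the scatter) and cannot be told apart from it here, which leaves compound 2 as the only compound standing clear of the other two. Nothing measured on these compounds accounts for the gap between bromo and methyl.

The compounds shown leave open how a chloro group, a methoxy group or an amine would fare at this carbon, and so whether the lower number belongs to bromo alone. On these data alone, whether bromo would bring the same gain at another carbon of this ring also stays open.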